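The source may report more compounds than this note shows. Statements on the series, on what has been measured and on what is new or still open speak of the compounds shown alone.

Working notes on the series. Compound 1 `C/C(=N\OC(=O)C(C)(C)C)c1ccc(Sc2cc(F)cc(C3CCOCC3)c2)cc1` is tested in a functional assay (blood) for inhibition, with Homo sapiens as the target (on this read-out lower numbers stand for stronger inhibition and higher numbers for weaker inhibition), and gives 40 nM. Compound 3 `C/C(=N/O)c1ccc(COc2cc(F)cc(C3CCOCC3)c2)cc1` gives 40 nM in this assay, a number that sits level with compound 1 within the scatter, so the two are not ranked against each other; together they hold the lowest numbers among the three measured compounds. Compound 2 `Fc1cc(Sc2ccc3c(c2)CC/C3=N\OCc2ccncc2)cc(C2CCOCC2)c1` gives 90 nM in this assay, a higher number than compound 1 by a margin beyond the scatter.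

Compound 4 `C/C(=N\OCC#N)c1ccc(Sc2cc(F)cc(C3CCOCC3)c2)cc1` is not yet measured. It differs from compound 1 in one place: cyanomethyl in place of (tert-butyl)carbonyl on an oxygen. Within the data shown here, no measured pair shows this exact change, so the size of the step cannot be read from a neighbour.

The expectation is a modest rise in the number, at or near the edge of the scatter, as the step of a 1.5-fold higher number from compound 1 to compound 4 (0.18 log units; within the scatter) in this assay; this rests on compound 2, whose value 90 nM shows that a different group on that oxygen is tolerated with only a moderate loss. Compound 4 is estimated at 60 nM in this assay, within a range of 25 nM to 150 nM.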

Compound 4, half-maximal inhibitory concentration: 20 nM
Compound 4: the middle estimate sits 3.0-fold (0.48 log units) above what was measured; the whole stated range lies above it.
By their numbers in this assay, from the lowest: compounds 4, 1 and 3 (each within the scatter of the next); then compound 2.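

In this assay, replacing (tert-butyl)carbonyl with cyanomethyl on the oxygen whose other neighbours are double-bonded nitrogen gives a 2.0-fold lower number from compound 1 to compound 4 (0.30 log units; within the scatter), so the two groups cannot be ranked. This pair shows that, on the core of compound 1, this oxygen need not carry a carbonyl for the number to stay in the same range, and that going from 6 heavy atoms to 3 in this group does not move the number beyond the scatter. Nothing available explains how the two groups come to read alike.

A single pair cannot show how far this holds for other groups on that oxygen. From the compounds shown here alone, whether a plain methyl, a longer chain ending in a nitrile, an amine or a carboxylic acid would stay within the scatter of compound 1 remains open.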